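The source may report more compounds than this note shows. Statements on the series, on what has been measured and on what is new or still open speak of the compounds shown alone.

Of the compounds shown here, three have been tested so far in an ADME assay on MT4 cells (Homo sapiens) for cytotoxicity, read by MTT assay, with a stated time of 5 days; on this read-out higher numbers stand for lower toxicity in this test and lower numbers for higher toxicity in this test. Compound 1 (`C=CCNc1cc(Oc2c(C)cc(/C=C/C#N)cc2C)nc(Nc2ccc(C#N)cc2)n1`) gives 3050 nM, compound 2 (`Cc1cc(/C=C/C#N)cc(C)c1Oc1cc(Cl)nc(Nc2ccc(C#N)cc2)n1`) gives 4310 nM, and compound 3 (`C=CCNc1cc(Oc2c(C)cc(/C=C/C#N)cc2C)cc(Nc2ccc(C#N)cc2)n1`) gives 82100 nM. Compound 3 therefore holds the highest number of the three, and its distance to each of the other two lies beyond the scatter. On this read-out, that marks it as the least toxic of the three in this test.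

Compound 4 (`Cc1cc(/C=C/C#N)cc(C)c1Oc1cc(Cl)nc(Nc2ccc(C#N)cc2)c1`) has not yet been measured. It differs from compound 3 in one place, with chloro in place of allylamino on an aromatic carbon, next to the ring nitrogen (chloro in place of allylamino on an aromatic carbon).

Going by the values given here, one measured step bears on this change, since the same exchange was made on the core of compound 1. It gave a 1.4-fold higher number from compound 1 to compound 2 (0.15 log units; within the scatter), which lies within the scatter and offers no reason to expect a real shift here. That exchange has been seen only once, however, and on a core that differs from that of compound 3, so the guidance it offers is limited and the range has to stay wide.

No step beyond the scatter is expected, and the estimated step is a 1.2-fold lower number from compound 3 to compound 4 (0.07 log units; within the scatter). For compound 4 the estimate is 70000 nM, with an expected range from 15000 nM to 200000 nM.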

Compound 4, half-maximal cytotoxic concentration: > 311000 nM
Compound 4: no number, only a limit; the forecaster's own chance of this, stated with the estimate: 20%; middle value at least 4.4-fold (0.64 log units) away from the limit.
By their numbers in this assay, from the lowest: compounds 1 and 2 (each within the scatter of the next); then compound 3. At a limit, above all of these: compound 4.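

On the core of compound 3, putting chloro in place of allylamino next to the ring nitrogen gives a real shift in this assay, with an at least 3.7-fold higher number from compound 3 to compound 4 (0.57 log units; beyond the scatter). On these data alone, compound 4 reads > 311000 nM, which is a limit of the assay and not a number, so the true size of this step is unknown and the printed step gives only its smallest size. Going by these compounds alone, the earlier pair, compound 1 and compound 2, showed the same exchange staying within the scatter, so compound 3 and compound 4 are the first pair to show that this exchange can go beyond the scatter, toward lower toxicity in this test.

Whether the exchange really acts differently on the two cores cannot be settled from these compounds: the same change on two cores in this assay, a 1.4-fold higher number (0.15 log units; within the scatter) from compound 1 to compound 2 and an at least 3.7-fold higher number (0.57 log units; beyond the scatter) from compound 3 to compound 4; the limit leaves it open whether they differ The compounds shown also leave open how other groups at this place would read in this assay, such as a methylamino group, a methoxy group or a morpholine ring, and so whether the shift follows the loss of allylamino or the arrival of chloro.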